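Furan in Place of Pyrazine: Expected Kinetic Solubility

The compounds below may be only part of what the source reports. "The series", "measured", "known", "first", "only" and "open" are said of these compounds alone.

Measured compounds:
compound 1 `Cc1cc(NCc2cnccn2)n2nc(C)c(-c3ccccc3)c2n1` gives 7100 nM
compound 2 `Cc1cc(N(C)Cc2ccccn2)n2nc(C)c(-c3ccccc3)c2n1` gives 17500 nM

Of the compounds shown here, two from this series have been measured in a physicochemical assay for solubility, read by HPLC, using the shake flask method, measured as kinetic solubility, with a stated time of 2 h, at pH 7.4; on this read-out higher numbers stand for higher solubility and lower numbers for lower solubility. Compound 1 stands at the lowest of the two numbers; its nearest neighbour, compound 2, shows a higher value, and that gap lies beyond the scatter of the assay. Within the data shown here, no single-change step between measured compounds is available, so compound 1 serves as the only anchor for the new analogue.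

Compound 3 `Cc1cc(NCc2ccco2)n2nc(C)c(-c3ccccc3)c2n1` differs from compound 1 by one change: furan-2-yl in place of pyrazin-2-yl on a saturated chain carbon bound to a nitrogen on an aromatic ring. The move from a six-membered ring with two hetero atoms to a five-membered ring with one hetero atom is a modest one. On this basis compound 3 is expected to show a small downward step, a 2.0-fold lower number from compound 1 to compound 3 (0.31 log units; beyond the scatter), a little beyond the scatter. The estimated value for compound 3 is 3500 nM, with a range from 1200 nM to 10000 nM.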

Compound 3, solubility: < 5000 nM
Compound 3 was reported as a limit; the forecaster's own chance of this, stated with the estimate: 5%; the middle value is on the limit's open side.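

In this assay compound 3 is reported only as a limit, < 5000 nM. Furan-2-yl in place of pyrazin-2-yl on a saturated chain carbon bound to a nitrogen on an aromatic ring gives the first single-change step in this series, an at least 1.4-fold lower number from compound 1 to compound 3 (0.15 log units; that floor lies within the scatter), so this position now has a direction, but only a floor for its size. The real size of the step stays unknown, and the reading rests on a single bound: the limit of < 5000 nM in this assay, at which 1 of the 3 values shown sits.

Among these compounds, compound 2 differs from compound 1 in more than one place and adds no step to this comparison. The compounds shown leave open how a carboxylic acid or a simple amine on the same saturated chain carbon would read in this assay.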